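The compounds below may be only part of what the source reports. "The series", "measured", "known", "first", "only" and "open" are said of these compounds alone.

Values so far in a functional assay on KB cells (Homo sapiens) for antiproliferative activity, read by sulforhodamine B assay, with a stated time of 48 h; on this read-out higher numbers stand for weaker inhibition of growth and lower numbers for stronger inhibition of growth
compound 1 `COc1ccc(S(=O)(=O)Nc2ccccc2CCc2ccc(C(=O)Nc3ccccc3N)cc2)cc1` gives 23 nM
compound 2 `COc1cccc(S(=O)(=O)Nc2ccccc2CCc2ccc(C(=O)Nc3ccccc3N)cc2)c1` gives 462 nM
compound 3 `Nc1ccccc1NC(=O)c1ccc(CCc2ccccc2NS(=O)(=O)c2ccc(Br)cc2)cc1` gives 124 nM

Compound 2 stands highest of the three numbers. The measured steps around it are a 20-fold higher number from compound 1 to compound 2 (1.30 log units; beyond the scatter) and a 3.7-fold lower number from compound 2 to compound 3 (0.57 log units; beyond the scatter). The remaining step is a 5.4-fold higher number from compound 1 to compound 3 (0.73 log units; beyond the scatter).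

Compound 4 `COc1ccc(S(=O)(=O)Nc2ccccc2CCc2ccc(C(=O)Nc3ccccc3N)cc2)cc1OC` arises from compound 2 by the change (methoxy in place of hydrogen on an aromatic carbon), that is, methoxy in place of hydrogen on an aromatic carbon, ortho to a methoxy group. The same difference reads 3-methoxyphenyl to 3,4-dimethoxyphenyl. For the measured compounds named here, the new group keeps the methoxy of compound 2 and adds the one found in compound 1 (23 nM). Going by the values given here, the large step to compound 1 therefore points to a lower number, but no measured compound carries two methoxy groups, so how much of that step carries over remains open. The expected change is a 5.1-fold lower number from compound 2 to compound 4 (0.71 log units; beyond the scatter), a modest to large drop in this assay that stops short of the full step. Compound 4 is estimated at 90 nM (expected range 25 nM to 350 nM) .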

Compound 4, concentration for 50% growth inhibition: 888 nM
Estimate against measurement, compound 4: 9.9-fold (0.99 log units) below; measured number above the stated range.
By their numbers in this assay, from the lowest: compound 1; then compound 3; then compounds 2 and 4 (each within the scatter of the next).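

In this assay, methoxy in place of hydrogen, ortho to a methoxy group, gives a 1.9-fold higher number from compound 2 to compound 4 (0.28 log units; within the scatter); the added group therefore does not separate these two compounds. Read from the other side, the same kind of change gives a 39-fold higher number from compound 1 to compound 4 (1.59 log units; beyond the scatter), so the low number of compound 1 does not survive in the 3,4-dimethoxyphenyl group, and the 4-methoxy effect seen earlier does not add to the 3-methoxy group. Against the bromo compound, 3,4-dimethoxyphenyl in place of 4-bromophenyl gives a 7.2-fold higher number from compound 3 to compound 4 (0.85 log units; beyond the scatter), which leaves compound 4 on the weak side of the series with compound 2.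

The data shown give no reason for these steps. On these data alone, whether a hydroxy group or a fluorine atom in place of the added methoxy would keep the number of compound 1 stays open.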